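This account rests on a few compounds, and the source may have more. Where it says the series, first, only, none or still open, it means among the compounds named here.

Compound 1, `CC(C)c1ccc(-c2nc(CN3CCCC3)nn2C)cc1`, is the starting point of this account. In an assay on membranes from Jurkat cells for displacement of a labelled ligand from Sigma intracellular receptor 2 (Homo sapiens), read by scintillation counting, with a stated time of 1 h (a higher number here means a weaker inhibitor, a lower number a stronger inhibitor), compound 1 gives 1000 nM. Compound 2, `Cn1nc(CN2CCCC2)nc1-c1cccc(-c2ccccc2)c1`, reads 1000 nM in this assay, the same as compound 1 at the digits given. Compound 3, `CC(C)(C)c1ccc(-c2nc(CN3CCCC3)nn2C2CC2)cc1`, reads 750 nM in this assay, a gap to compound 1 that lies within the usual scatter of repeated measurements. Compound 1 therefore stands level with compound 2, and compound 3 cannot be told apart from either on these numbers alone.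

The step to compound 4, `Cn1nc(CN2CCCC2)nc1-c1ccc(C2CC2)cc1`, is a single change: cyclopropyl in place of isopropyl on an aromatic carbon. Among the compounds with values here, no pair of measured compounds differs in just this way, so the data hold no step of this kind to lean on; the three measured values simply lie close together.

With nothing to suggest a shift in either direction, compound 4 is expected to stay near compound 1, the step of no change at the digits printed from compound 1 to compound 4 (within the scatter) being no larger than the scatter. The estimate for compound 4 in this assay is 1000 nM, with a range from 400 nM to 2500 nM, because compound 1 sits at 1000 nM and the change is small in count and in kind.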

Compound 4, inhibition constant: 1000 nM
The estimate for compound 4 equals the measured number at the digits printed; measured number inside the range.
By their numbers in this assay, from the lowest: compounds 3, 1, 2 and 4 (each within the scatter of the next).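

In this assay, within the data shown here, putting cyclopropyl in place of isopropyl on an aromatic carbon, para to a large group, gives no change at the digits printed from compound 1 to compound 4 (within the scatter), and this is the only comparison in the set that isolates a single change. Among these compounds, it shows that, at this position and in this assay, a three-membered ring of carbon can replace the open isopropyl group, which has the same count of heavy atoms, with no change that can be told from the scatter, something the earlier compounds, which differ in more than one place, could not show. No measurement is at hand that would explain this result.

This one step covers only these two groups, both made of carbon alone, so it says nothing about how a different kind of group, such as an amine, a carboxylic acid or a longer chain, would read at the same position. Compound 4 reads 1000 nM. Going by these compounds, whether any change at this position can move the number beyond the scatter stays open, as does whether the same exchange would behave alike on a core carrying a different group elsewhere.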